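This account rests on a few compounds, and the source may have more. Where it says the series, first, only, none or still open, it means among the compounds named here.

Measured compounds:
Compound 1 `NC(=O)c1c(NC(=O)c2ccccc2Cl)sc2c1CCN(C(=S)Nc1ccccc1F)C2` gives 28700 nM.
Compound 2 `NC(=O)c1c(NC(=O)c2ccccc2Cl)sc2c1CCN(C(=S)Nc1ccccc1Br)C2` gives 24600 nM.
Compound 3 `NC(=O)c1c(NC(=O)c2ccccc2C(F)(F)F)sc2c1CCN(C(=S)Nc1ccccc1F)C2` gives only a limit, > 50000 nM.

All three were tested in a functional assay on HeLa cells (Homo sapiens) for antiproliferative activity, with a stated time of 24 h; a lower number here means a stronger inhibitor, a higher number a weaker inhibitor. Compound 1 and compound 2 share a core and differ only in one place: bromo in place of fluoro on an aromatic carbon. This change produced a 1.2-fold lower number from compound 1 to compound 2 (0.07 log units; within the scatter). Compound 3 differs from compound 1 in the other half of the molecule: trifluoromethyl in place of chloro on an aromatic carbon. The value of compound 3 is a limit of the assay and not a number, (the limit of > 50000 nM in this assay, at which 1 of the 3 values shown sits). The step accordingly reads an at least 1.7-fold higher number from compound 1 to compound 3 (0.24 log units; that floor lies within the scatter).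

Compound 4 `NC(=O)c1c(NC(=O)c2ccccc2C(F)(F)F)sc2c1CCN(C(=S)Nc1ccccc1Br)C2` has not yet been measured in this assay. It differs from compound 3 by bromo in place of fluoro on an aromatic carbon, and this is the same change, at the same place, that separates compound 1 from compound 2. Because a 1.2-fold lower number from compound 1 to compound 2 (0.07 log units; within the scatter) lay within the scatter, the step from compound 3 to compound 4 is expected to be similarly small, a step that the limit leaves unreadable from compound 3 to compound 4, so that compound 4 would most likely also fall at or near the limit. Compound 4 is therefore estimated at 55000 nM, with an expected range from 30000 nM to 120000 nM.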

Compound 4, half-maximal inhibitory concentration: > 50000 nM
Compound 4: no number, only a limit; the forecaster's own chance of this, stated with the estimate: 65%; the middle value is on the limit's open side.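

In this assay compound 4 gives > 50000 nM, which is a limit of the assay and not a number. Trifluoromethyl in place of chloro on the 2-bromophenyl side reads as an at least 2.0-fold higher number from compound 2 to compound 4 (0.30 log units; that floor lies within the scatter), while the step from bromo to fluoro between the two trifluoromethyl compounds cannot be read. Set beside the earlier step, the change points the same way on both cores, but each reading is only a floor, so this does not show that its size carries from one core to the other: the same change on two cores in this assay, an at least 1.7-fold higher number (0.24 log units; that floor lies within the scatter) from compound 1 to compound 3 and an at least 2.0-fold higher number (0.30 log units; that floor lies within the scatter) from compound 2 to compound 4; the limit leaves it open whether they differ.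

The compounds shown leave open how far past the limit compound 3 and compound 4 lie: the limit of > 50000 nM in this assay, at which 2 of the 4 values shown sit. Also open, going by these compounds, is whether a methoxy group or a nitrile in place of chloro would give a readable number on either core, and with it a step that could be compared across the two.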